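A Chlorophenyl Triazole Ester Awaits Its Number

This account rests on a few compounds, and the source may have more. Where it says the series, first, only, none or still open, it means among the compounds named here.

In a functional assay on DU-145 cells (Homo sapiens) for antiproliferative activity, read by MTT assay, with a stated time of 48 h (on this read-out higher numbers stand for weaker inhibition and lower numbers for stronger inhibition), compound 3 `COc1cccc(-n2cc(COC(=O)/C(C)=C/CC/C(C)=C/CC/C(C)=C/CC[C@@H]3[C@@]4(C)CCC(=O)C(C)(C)[C@H]4CC[C@@]3(C)O)nn2)c1` stands only at a limit of the assay, > 150000 nM. Compound 1 `C/C(=C\CC/C(C)=C/CC[C@@H]1[C@@]2(C)CCC(=O)C(C)(C)[C@H]2CC[C@@]1(C)O)CC/C=C(\C)C(=O)OCc1cn(-c2ccccc2C)nn1` likewise gives only a limit in this assay, > 150000 nM. Compound 2 `C#CCOC(=O)/C(C)=C/CC/C(C)=C/CC/C(C)=C/CC[C@@H]1[C@@]2(C)CCC(=O)C(C)(C)[C@H]2CC[C@@]1(C)O`, which carries an ethynyl on the saturated chain carbon bound to an oxygen next to a carbonyl group, gives 46100 nM in this assay, and an at least 3.2-fold lower number from compound 1 to compound 2 (0.51 log units; beyond the scatter). The move from compound 1 to compound 3 is a step that the two limits leave unreadable from compound 1 to compound 3, and it cannot be sized because of the limit of > 150000 nM in this assay, at which 2 of the 3 values shown sit. Compound 4 `C/C(=C\CC/C(C)=C/CC[C@@H]1[C@@]2(C)CCC(=O)C(C)(C)[C@H]2CC[C@@]1(C)O)CC/C=C(\C)C(=O)OCc1cn(-c2ccc(Cl)cc2)nn1` differs from compound 3 in one place: 4-chlorophenyl in place of 3-methoxyphenyl on an aromatic nitrogen. Among the measured compounds shown here, no measured step bears directly on this exchange; the only change of the aryl group seen so far, from compound 1 to compound 3, sits at the limit at both ends, and the one readable step concerns a different position. One therefore expects compound 4 to remain near that limit, with a number no higher from compound 3 to compound 4 (the limit leaves the size open) meaning no step beyond the scatter. The estimate for compound 4 in this assay is 150000 nM, between 50000 nM and 400000 nM.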

Compound 4, half-maximal inhibitory concentration: > 150000 nM
Compound 4: only a limit was reported (the forecaster's own chance of this, stated with the estimate: 70%); the middle value lies on the limit itself.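

With 4-chlorophenyl on the aromatic nitrogen, a third aryl group now ends at the limit of this assay, and this one carries a chlorine rather than a methyl or a methoxy group. Replacing ethynyl with 1-(4-chlorophenyl)-1H-1,2,3-triazol-4-yl gives an at least 3.2-fold higher number from compound 2 to compound 4 (0.51 log units; beyond the scatter), so this second aryl triazole repeats, in the direction from the ethynyl compound, the gap already seen with the 2-methylphenyl group. The steps from compound 3 to compound 4 and from compound 1 to compound 4 cannot be read, because the values at both ends are limits: the limit of > 150000 nM in this assay, at which 3 of the 4 values shown sit.

Going by these compounds, how far these three aryl triazole compounds differ from one another therefore remains open. On these data alone, it is also open whether a phenyl ring carrying an amine or a carboxylic acid on that aromatic nitrogen would bring the number within the measurable range.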